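A few compounds are considered here, and "the series" means these few. Any claim that something is new, unique, unknown or untested is made for them only; others in the source may bear on it.

In a functional assay, read by spectrophotometry, with a stated time of 2 h (on this read-out higher numbers stand for weaker inhibition and lower numbers for stronger inhibition), compound 1 `COC(=O)C1=C(C)NC(=O)NC1c1ccc(OC)cc1` gives 31.7 ug/mL and compound 2 `COC(=O)C1=C(C)NC(=O)NC1c1ccc([N+](=O)[O-])cc1` gives 27.8 ug/mL. These two values lie within the scatter of each other, so compound 2 cannot be separated from compound 1 on these numbers. Compound 3 `CCOC(=O)C1=C(C)NC(=O)NC1c1ccc([N+](=O)[O-])cc1` differs from compound 2 in one place: methyl in place of hydrogen on a saturated chain carbon bound to an oxygen next to a carbonyl group. This is methyl in place of hydrogen on a saturated chain carbon bound to an oxygen next to a carbonyl group, or methoxycarbonyl to ethoxycarbonyl.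

Going by the values given here, the only measured step is a 1.1-fold lower number from compound 1 to compound 2 (0.06 log units; within the scatter), with nitro in place of methoxy on an aromatic carbon. It lies elsewhere on the shared core and bears on this change only indirectly. Among the compounds with values here, no measured step covers the new place, so no step beyond the scatter is expected in this assay, in either direction. The estimate for compound 3 is 28 ug/mL, with an expected range of 14 ug/mL to 56 ug/mL. The expected change is a 1.0-fold higher number from compound 2 to compound 3 (0.00 log units; within the scatter).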

Compound 3, half-maximal inhibitory concentration: 33.3 ug/mL
The estimate for compound 3 lay 1.2-fold (0.08 log units) below the measured number, within the range that was stated.
By their numbers in this assay, from the lowest: compounds 2, 1 and 3 (each within the scatter of the next).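

In this assay, the change from methoxycarbonyl to ethoxycarbonyl gives a 1.2-fold higher number from compound 2 to compound 3 (0.08 log units; within the scatter), so one added methyl on a saturated chain carbon bound to an oxygen next to a carbonyl group produces no step beyond the scatter. Going by these compounds alone, this is the first reading at this place, since the earlier step concerned only an aromatic carbon, and neither of the two single changes now leaves the scatter. No measured information on the compounds bears on this result.

From the compounds shown here alone, whether a longer chain such as propyl or butyl at this place, or a carboxylic acid or an amide in place of the methoxycarbonyl group, would give a step beyond the scatter remains open. The shown ethoxycarbonyl change also rests on a single pair carrying nitro, so its reading with methoxy on the aromatic carbon remains open too.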